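The source may report more compounds than this note shows. Statements on the series, on what has been measured and on what is new or still open speak of the compounds shown alone.

Working notes on the series. Of the compounds shown here, three have been measured; all share one core and differ only in the benzyl group on the amide-type nitrogen. Compound 1 `Cc1cc(C)cc(CN2CCc3ncn(COCc4ccccc4)c3/C(=C/c3ccccc3)C2=O)c1` gives 31300 nM in a functional assay on A2780 cells (Homo sapiens) for inhibition, read by MTT assay, with a stated time of 72 h; on this read-out lower numbers stand for stronger inhibition and higher numbers for weaker inhibition. Compound 2 `Cc1cccc(CN2CCc3ncn(COCc4ccccc4)c3/C(=C/c3ccccc3)C2=O)c1` gives 26300 nM in this assay. Compound 3 `O=C1/C(=C\c2ccccc2)c2c(ncn2COCc2ccccc2)CCN1Cc1ccc(Cl)cc1` gives 22200 nM in this assay. Compound 3 has the lowest of the three numbers, but the steps that lead to it are small: a 1.4-fold lower number from compound 1 to compound 3 (0.15 log units; within the scatter) and a 1.2-fold lower number from compound 2 to compound 3 (0.07 log units; within the scatter), both within the scatter, as is a 1.2-fold lower number from compound 1 to compound 2 (0.08 log units; within the scatter). Nothing in these numbers separates the three benzyl groups from one another.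

Compound 4 `CC(C)(C)c1ccc(CN2CCc3ncn(COCc4ccccc4)c3/C(=C/c3ccccc3)C2=O)cc1` is not yet measured. It differs from compound 3 as follows: tert-butyl in place of chloro on an aromatic carbon. The measured steps that bear on this change are those that also alter the benzyl ring, a 1.4-fold lower number from compound 1 to compound 3 (0.15 log units; within the scatter) and a 1.2-fold lower number from compound 2 to compound 3 (0.07 log units; within the scatter), and neither went beyond the scatter. Among the compounds with values here, no measured step exchanges chloro for tert-butyl, so the size of that particular change is unknown. On the evidence of the benzyl variations seen so far, the expected step is a 1.1-fold higher number from compound 3 to compound 4 (0.05 log units; within the scatter), no movement beyond the scatter. For compound 4 in this assay the estimate is 25000 nM, with a range from 10000 nM to 60000 nM.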

Compound 4, half-maximal inhibitory concentration: 23900 nM
Estimate against measurement, compound 4: 1.0-fold (0.02 log units) above; low and high end bracket the measured number.
By their numbers in this assay, from the lowest: compounds 3, 4, 2 and 1 (each within the scatter of the next).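

The exchange of chloro (1 heavy atom) for tert-butyl (4 heavy atoms), on an aromatic carbon para to a large group, gives a 1.1-fold higher number from compound 3 to compound 4 (0.03 log units; within the scatter) in this assay, so this larger group leaves the number within the scatter of the chloro compound, a test of size at this place that the earlier methyl and chloro variations did not provide. The steps of a 1.1-fold lower number from compound 2 to compound 4 (0.04 log units; within the scatter) and a 1.3-fold lower number from compound 1 to compound 4 (0.12 log units; within the scatter) are also within the scatter, and the four benzyl groups, substituted at different places and with different groups, remain unseparated on this read-out. No measurement is available that would account for this flat result.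

All four benzyl substituents shown are free of hydrogen-bond donors and acceptors and carry no net charge, so it remains open whether an amine or a carboxylic acid at this place would move the number beyond the scatter. Also open, as far as these compounds go, is whether changes away from the benzyl group, on the rest of the shared core, would have any larger effect in this assay.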